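A few compounds are considered here, and "the series" means these few. Any claim that something is new, unique, unknown or untested is made for them only; others in the source may bear on it.

Measured compounds:
compound 1, `CC1(C)N=C(N)N=C(N)N1c1ccc(SCC(=O)Nc2ccc(S(=O)(=O)F)cc2)cc1`: 7.52
compound 2, `CC1(C)N=C(N)N=C(N)N1c1ccc(SCC(=O)Nc2ccc(S(=O)(=O)F)cc2)c(Cl)c1`: 7.42
compound 3, `CC1(C)N=C(N)N=C(N)N1c1ccc(CCCCc2cc(Cl)ccc2S(=O)(=O)F)c(Cl)c1`: 7.06

All three were tested in an assay on isolated protein for inhibition of Dihydrofolate reductase (Mus musculus); on this read-out higher numbers stand for higher potency (the scale is a negative logarithm) and lower numbers for lower potency. Compound 1 and compound 2 share the same core and differ in one place: hydrogen in place of chloro on an aromatic carbon. This change gave a number 0.10 log units higher from compound 2 to compound 1 (within the scatter), so the two are not distinguished by this assay. Compound 3 carries a different core; how its core differs from that of compound 2 is not broken down here. In this assay compound 3 gives 7.06, the lowest number of the three, and its distance from each of the other two lies beyond the scatter.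

Compound 4, `CC1(C)N=C(N)N=C(N)N1c1ccc(CCCCc2ccccc2S(=O)(=O)F)c(Cl)c1`, has not yet been measured. It differs from compound 3 in one place: hydrogen in place of chloro on an aromatic carbon. Going by the values given here, this is the same kind of change as the one from compound 2 to compound 1, but the surroundings are not the same: there the carbon is ortho to a large group and meta to a large group, here it is meta to a large group and para to a fluorosulfonyl group. The step from compound 3 to compound 4 is expected to be a number 0.09 log units higher from compound 3 to compound 4 (within the scatter), beside the earlier one, because a number 0.10 log units higher from compound 2 to compound 1 (within the scatter) was small and the same kind of change is made. Compound 4 is therefore estimated at 7.15, with a likely range from 6.75 to 7.55.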

Compound 4, logarithm of the reciprocal of the active concentration, log(1/C): 7.77
Compound 4: the middle estimate sits 0.62 log units below what was measured; the whole stated range lies below it.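

In this assay, putting hydrogen in place of chloro on the ring that carries the fluorosulfonyl group gave a number 0.71 log units higher from compound 3 to compound 4 (beyond the scatter). This is the clearest lesson of the pair: the same swap of chloro for hydrogen does not have one fixed size that can be carried from one core to another in this series, as the two steps set side by side make plain: the same change on two cores in this assay, a number 0.10 log units higher (within the scatter) from compound 2 to compound 1 and a number 0.71 log units higher (beyond the scatter) from compound 3 to compound 4, 0.61 log units apart, beyond the scatter of two such steps What this does not show is which difference between the two cores or the two surroundings of the chloro group sets the size of the step, and two pairs cannot say how the swap would behave on a third core.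

The compounds shown leave open whether another small group at the same place on the core of compound 4, such as fluoro, methyl or methoxy, would give a number closer to that of the chloro compound or to that of the hydrogen compound. They also leave open whether the step from chloro to hydrogen would keep its size if the chain joining the two rings in compound 3 and compound 4 were shorter or longer.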